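The source may hold more compounds than are shown below. What is called first, only, known or untested is meant among the compounds shown, and "the series" means these compounds.

Working notes on the series. Compound 2 `COC(=O)CC(=O)NC1=CS(=O)(=O)O[C@@]12[C@@H](CO[Si](C)(C)C(C)(C)C)O[C@@H](n1cc(C)c(=O)n(C)c1=O)[C@@H]2O[Si](C)(C)C(C)(C)C` sits alongside compound 1 `Cc1cn([C@@H]2O[C@H](CO[Si](C)(C)C(C)(C)C)[C@@]3(OS(=O)(=O)C=C3NCCC(N)=O)[C@H]2O[Si](C)(C)C(C)(C)C)c(=O)n(C)c1=O` and compound 3 `Cc1cn([C@@H]2O[C@@H]3COC(=O)[C@]3(OS(C)(=O)=O)[C@H]2O)c(=O)[nH]c1=O`. Going by the values given here, in a functional assay on MT4 cells (Homo sapiens) (a lower number here means that less compound is tolerated, a higher number that more compound is tolerated), compound 2 gives 11900 nM, one of only two numbers in hand, and compound 1 with 20000 nM lies within the scatter of it; the single measured step is a 1.7-fold lower number from compound 1 to compound 2 (0.23 log units; within the scatter). For compound 3 this assay reports only a limit, >= 250000 nM. Compound 4 `Cc1cn([C@@H]2O[C@H](CO[Si](C)(C)C(C)(C)C)[C@@]3(OS(=O)(=O)C=C3NCC(=O)OCc3ccccc3)[C@H]2O[Si](C)(C)C(C)(C)C)c(=O)n(C)c1=O` carries (benzyloxycarbonyl)methyl in place of ((methoxycarbonyl)methyl)carbonyl on an amine nitrogen. Among the compounds with values here, the one step that bears on this change stayed within the scatter, so no step beyond the scatter is expected for compound 4 in this assay, the expected step being a 1.0-fold higher number from compound 2 to compound 4 (0.00 log units; within the scatter). Compound 4 is accordingly estimated at 12000 nM, with a range from 5000 nM to 30000 nM.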

Compound 4, half-maximal cytotoxic concentration: 250000 nM
Compound 4: the middle estimate sits 21-fold (1.32 log units) below what was measured; the whole stated range lies below it.
By their numbers in this assay, from the lowest: compounds 2 and 1 (each within the scatter of the next); then compound 4.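

With (benzyloxycarbonyl)methyl on this amine nitrogen, the substituent now matters in this assay, which the earlier pair could not show: the change gives a 21-fold higher number from compound 2 to compound 4 (1.32 log units; beyond the scatter). The comparison with the carbamoylethyl substituent points the same way, with a 13-fold higher number from compound 1 to compound 4 (1.10 log units; beyond the scatter). The number for compound 4 stands level with a limit reported in the series: the limit of >= 250000 nM in this assay, at which 1 of the 4 values shown sits.

The compounds shown do not separate the aromatic ring, the benzyl ester and the loss of the carbonyl on the nitrogen as the source of the step. A plain benzyl group or a carboxylic acid on this amine nitrogen would bear on that question.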